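Acrylamide series: substitution on the amide nitrogen

The source may hold more compounds than are shown below. What is called first, only, known or untested is meant among the compounds shown, and "the series" means these compounds.

Compound 1 `C=CC(=O)Nc1nc(-c2ccccc2)cs1` gives 6600 nM in a functional assay on HT-29 cells (Homo sapiens) for antiproliferative activity, read by MTT assay, with a stated time of 72 h (on this read-out higher numbers stand for weaker inhibition and lower numbers for stronger inhibition), the lowest of the three numbers measured. Compound 2 `C=CC(=O)Nc1nc(-c2ccc(C)cc2)cs1` gives 16100 nM and compound 3 `C=CC(=O)Nc1nc(-c2ccccc2)c(C(=O)OCC)s1` gives 18000 nM; both steps, a 2.4-fold higher number from compound 1 to compound 2 (0.39 log units; beyond the scatter) and a 2.7-fold higher number from compound 1 to compound 3 (0.44 log units; beyond the scatter), are modest rises from compound 1. Compound 4 `C=CC(=O)N(Cc1cccnc1)c1nc(-c2ccccc2)cs1` differs from compound 1 by (pyridin-3-yl)methyl in place of hydrogen on an amide-type nitrogen. Neither measured step touches the amide-type nitrogen, so neither bears directly on this change; they show only that the two additions made so far to the core of compound 1 raised the number modestly. A rise of similar or somewhat larger size is therefore expected for compound 4, estimated at 20000 nM with a range of 5000 nM to 80000 nM, a step of a 3.0-fold higher number from compound 1 to compound 4 (0.48 log units; beyond the scatter).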

Compound 4, half-maximal inhibitory concentration: > 30000 nM
Compound 4 ended at the assay's limit; the forecaster's own chance of this, stated with the estimate: 15%; middle value at least 1.5-fold (0.17 log units) away from the limit.
By their numbers in this assay, from the lowest: compound 1; then compounds 2 and 3 (each within the scatter of the next). At a limit, above all of these: compound 4.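

In this assay compound 4 stands at a limit of the assay, > 30000 nM. Substitution at the amide-type nitrogen is thus shown for the first time to matter: (pyridin-3-yl)methyl in place of hydrogen gives an at least 4.5-fold higher number from compound 1 to compound 4 (0.65 log units; beyond the scatter). Only a minimum can be read for this step, and its full size remains unknown: the limit of > 30000 nM in this assay, at which 1 of the 4 values shown sits.

On these data alone, whether a small methyl on this nitrogen would keep the value of compound 1 stays open. Also open, as far as these compounds go, is whether benzyl, or a chain ending in an amine, would behave like (pyridin-3-yl)methyl.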